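Compound 3: replacing the hydroxycyclohexyl ether with dinitrophenyl

A few compounds are considered here, and "the series" means these few. Any claim that something is new, unique, unknown or untested is made for them only; others in the source may bear on it.

For the measured compounds named here, only one number anchors this small series so far. Going by the values given here, in a functional assay on HeLa cells (Homo sapiens) for inhibition, read by CCK-8 assay, with a stated time of 48 h (on this read-out higher numbers stand for weaker inhibition and lower numbers for stronger inhibition), compound 1 `O=C(NCCNS(=O)(=O)c1ccc(-c2ccccc2O[C@H]2CC[C@H](O)CC2)s1)Nc1ccc([N+](=O)[O-])cc1` gives 10500 nM, the sole numeric value available. Compound 2 `O=C(NCCNS(=O)(=O)c1ccc(-c2ccccc2OCc2cccc(O)c2)s1)Nc1cc(Cl)cc(Cl)c1` is reported only as a limit, > 50000 nM. Compound 1 and compound 2 differ in more than one place, so no measured single change is available as a guide.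

The next compound to be read is compound 3 `O=C(NCCNS(=O)(=O)c1ccc(-c2ccccc2Oc2ccc([N+](=O)[O-])c([N+](=O)[O-])c2)s1)Nc1ccc([N+](=O)[O-])cc1`. It has 3,4-dinitrophenyl in place of 4-hydroxycyclohexyl on an oxygen on an aromatic ring, and the rest of compound 1 is unchanged: 3,4-dinitrophenyl in place of 4-hydroxycyclohexyl on an oxygen on an aromatic ring.

Among the compounds with values here, with no measured step for this exchange, the expectation in this assay rests on compound 1 at 10500 nM, and no shift beyond the scatter is expected, in either direction. The range is kept wide, and a result reported only as a limit remains possible. In numbers, the expected change is a 1.1-fold higher number from compound 1 to compound 3 (0.06 log units; within the scatter). For compound 3 the estimated value is 12000 nM, with an expected range of 3000 nM to 50000 nM.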

Compound 3, half-maximal inhibitory concentration: > 20000 nM
Compound 3: a limit, no number; the forecaster's own chance of this, stated with the estimate: 25%; at least 1.6-fold (0.22 log units) between middle value and limit.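

In this assay, compound 3 is reported only as a limit: the limit of > 20000 nM in this assay, at which 1 of the 3 values shown sits. This gives the series its first step at a single place, on an oxygen on an aromatic ring, where 3,4-dinitrophenyl in place of 4-hydroxycyclohexyl gives an at least 1.9-fold higher number from compound 1 to compound 3 (0.27 log units; that floor lies within the scatter); this is a floor and not a measured size, so the real step may be close to the scatter or much larger. On these data alone, the exchange therefore brings no gain in inhibition, which shows that this larger aromatic group with 0 hydrogen-bond donors does not improve on 4-hydroxycyclohexyl at this oxygen, though how far it falls short stays unknown.

The compounds shown leave open which part of the exchange matters: the loss of the hydroxyl, the change to an aromatic ring, or the two nitro groups. An unsubstituted phenyl on this oxygen, or an amine or a carboxylic acid in place of the hydroxyl on the cyclohexyl ring, would begin to separate these parts.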